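Thiophen-3-yl in Place of Phenyl: Expecting Compound 4

This account rests on a few compounds, and the source may have more. Where it says the series, first, only, none or still open, it means among the compounds named here.

Compound 1 `COc1ccc(/C=C/C(=O)c2ccc(OC)c3c2OC(C)(C)C=C3)c(F)c1` in a functional assay on SW-620 cells (Homo sapiens) for antiproliferative activity, read by MTT assay, with a stated time of 24 h (on this read-out lower numbers stand for stronger inhibition and higher numbers for weaker inhibition), gives 6570 nM.
Compound 2 `COc1ccc(C(=O)/C=C/c2cccc([N+](=O)[O-])c2)c2c1C=CC(C)(C)O2` gives 4090 nM.
Compound 3 `COc1ccc(C(=O)/C=C/c2ccccc2)c2c1C=CC(C)(C)O2` gives only a limit of the assay, > 10000 nM.

Compound 3 thus stands at the limit of > 10000 nM in this assay, at which 1 of the 3 values shown sits, and its number is known only as a limit. The two measured steps leading into it read an at least 1.5-fold higher number from compound 1 to compound 3 (0.18 log units; that floor lies within the scatter) and an at least 2.4-fold higher number from compound 2 to compound 3 (0.38 log units; beyond the scatter), both toward weaker inhibition, the second beyond the scatter.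

Compound 4 `COc1ccc(C(=O)/C=C/c2ccsc2)c2c1C=CC(C)(C)O2` differs from compound 3 in one place: thiophen-3-yl in place of phenyl on a double-bonded chain carbon bound to a double-bonded chain carbon. Going by the values given here, no measured step exchanges this group for a thiophene; the only comparable steps swap aryl groups on the same chain carbon, as in a 1.6-fold lower number from compound 1 to compound 2 (0.21 log units; within the scatter), which stayed within the scatter, and the two steps into the limit named above. All three aryl groups measured on this chain carbon give weak inhibition, so a small heteroaryl ring is expected to leave compound 4 near the limit as well.

Compound 4 is therefore expected to give about 12000 nM. For compound 4 the estimated range runs from 5000 nM to 30000 nM. The expected step is a step that the limit leaves unreadable from compound 3 to compound 4, nothing beyond the scatter.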

Compound 4, half-maximal inhibitory concentration: > 10000 nM
Compound 4: a limit, no number; the forecaster's own chance of this, stated with the estimate: 60%; the middle value is on the limit's open side.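

In this assay compound 4 gives > 10000 nM, a limit of the assay and not a number. Measured against the two compounds with numbers, there is an at least 2.4-fold higher number from compound 2 to compound 4 (0.38 log units; beyond the scatter) and an at least 1.5-fold higher number from compound 1 to compound 4 (0.18 log units; that floor lies within the scatter), so only the first step shows thiophen-3-yl on this chain carbon giving weaker inhibition beyond the scatter, while the step between the two limits cannot be read. A five-membered ring with a sulfur now joins phenyl on this chain carbon, and the limit is no longer a single case: the limit of > 10000 nM in this assay, at which 2 of the 4 values shown sit.

As far as these compounds go, how far compound 3 and compound 4 lie past the limit stays open, so the exchange of phenyl for thiophen-3-yl has no size here. Also open, from the compounds shown here alone, is whether a pyridine ring, or an amine or a carboxylic acid on the phenyl ring, would bring a number back within range.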